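This account rests on a few compounds, and the source may have more. Where it says the series, first, only, none or still open, it means among the compounds named here.

Measured so far in one assay:

Compound 1, `O=C1c2ccccc2N(Cc2ccc(Cl)cc2)S(=O)(=O)N1Cc1ccccc1`: 60000 nM
Compound 2, `O=C1c2ccccc2N(Cc2ccccc2)S(=O)(=O)N1Cc1ccc(Cl)cc1`: 60000 nM
Compound 3, `O=C1c2ccccc2N(Cc2ccccc2Cl)S(=O)(=O)N1Cc1ccccc1`: 60000 nM

In a functional assay on MRC5 cells (Homo sapiens) (a lower number here means that less compound is tolerated, a higher number that more compound is tolerated), compound 1 gives 60000 nM, and compound 3 gives 60000 nM. The two differ in one place: 2-chlorophenyl in place of 4-chlorophenyl on a saturated chain carbon bound to a sulfonamide nitrogen in a ring. That change made the step of no change at the digits printed from compound 1 to compound 3 (within the scatter). Compound 2 gives 60000 nM, level with compounds 1 and 3 at the digits shown; how the core of compound 2 differs from the core of compound 1 is not broken down here.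

Compound 4, `O=C1c2ccccc2N(Cc2ccccc2)S(=O)(=O)N1Cc1ccccc1Cl`, is not yet measured. It differs from compound 2 by 2-chlorophenyl in place of 4-chlorophenyl on a saturated chain carbon bound to an amide-type nitrogen in a ring. Within the data shown here, this is the same kind of change as the one from compound 1 to compound 3, but the place is not identical: there the carbon was bound to a sulfonamide nitrogen in a ring, here it is bound to an amide-type nitrogen in a ring. Since the earlier step of no change at the digits printed from compound 1 to compound 3 (within the scatter) and the three values all sit together, compound 4 is expected to show a step of no change at the digits printed from compound 2 to compound 4 (within the scatter) and to give an estimated 60000 nM in this assay, likely between 30000 nM and 120000 nM.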

Compound 4, half-maximal cytotoxic concentration: 60000 nM
Compound 4: the middle estimate sits on the measured number at the digits printed; the measured number falls inside the stated range.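

In this assay, 2-chlorophenyl in place of 4-chlorophenyl on a saturated chain carbon bound to an amide-type nitrogen in a ring gave no change at the digits printed from compound 2 to compound 4 (within the scatter), and this step matches the earlier one on a carbon bound to a sulfonamide nitrogen in a ring: the same change on two cores in this assay, no change at the digits printed (within the scatter) from compound 1 to compound 3 and no change at the digits printed (within the scatter) from compound 2 to compound 4, 1.0-fold (0.00 log units) apart, within the scatter of two such steps. Within these four compounds, then, the change carries from one core to the other with no difference that stands out from the scatter. It does not show that the change would carry to other cores, and with all four compounds level at the digits printed, it cannot tell whether this swap is without consequence in general or whether this read-out simply does not separate these compounds.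

The compounds shown leave open whether a carboxylic acid or an amine on the benzyl ring would shift the value from that of compound 4. They also leave open what a longer chain between the ring nitrogen and the phenyl ring would do.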